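Ethoxy in place of (benzyloxy)amino on a carbonyl carbon

The source may report more compounds than this note shows. Statements on the series, on what has been measured and on what is new or still open speak of the compounds shown alone.

In a functional assay on HCT-116 cells (Homo sapiens) (on this read-out lower numbers stand for stronger inhibition and higher numbers for weaker inhibition), compound 1 (`COc1cc(NC(C)CCCNC(=O)NCCCCCO)c2ncccc2c1`) gives 29000 nM and compound 2 (`COc1cc(NC(C)CCCNC(=O)NOCc2ccccc2)c2ncccc2c1`) gives 14000 nM as the lower of the two numbers. Compound 3 (`CCOC(=O)NCCCC(C)Nc1cc(OC)cc2cccnc12`) is still unmeasured and differs from compound 2 as follows: ethoxy in place of (benzyloxy)amino on a carbonyl carbon with ethoxy in place of (benzyloxy)amino on a carbonyl carbon. Among the compounds with values here, the one measured step bearing on this is a 2.1-fold lower number from compound 1 to compound 2 (0.32 log units; beyond the scatter) which is modest and brought in benzyloxy in place of 5-hydroxypentyl on an amide-type nitrogen, so with benzyloxy gone a similarly modest move to a higher number is expected in this assay and not a large one. The expected change is a 1.7-fold higher number from compound 2 to compound 3 (0.23 log units; within the scatter) by this estimate. In this assay the estimate for compound 3 is 24000 nM with an expected range from 9000 nM to 60000 nM overall.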

Compound 3, half-maximal inhibitory concentration: 28000 nM
The estimate for compound 3 lay 1.2-fold (0.07 log units) below the measured number; the measured number falls inside the stated range.
By their numbers in this assay, from the lowest: compounds 2, 3 and 1 (each within the scatter of the next, the first and the last beyond it).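

In this assay, ethoxy on the carbonyl carbon, with no ring and no hydrogen-bond donor, gives a 2.0-fold higher number from compound 2 to compound 3 (0.30 log units; within the scatter), and in place of (5-hydroxypentyl)amino it gives a 1.0-fold lower number from compound 1 to compound 3 (0.02 log units; within the scatter). At this position, therefore, a much smaller group with no six-membered aromatic ring stays within the scatter of both larger groups. Nothing available explains these steps. On these data alone, it remains open whether a primary amine or a carboxylic acid on this carbonyl carbon would move the number further. A longer alkoxy chain is equally untested here.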